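The source may report more compounds than this note shows. Statements on the series, on what has been measured and on what is new or still open speak of the compounds shown alone.

Compound 1 `O=C(Nc1ccccc1)c1cc2cc([N+](=O)[O-])ccc2o1` was measured in a physicochemical assay for solubility (a lower number here means a less soluble compound, a higher number a more soluble compound), where compound 1 gives 25 ug/mL. Compound 3 `COC(=O)c1cccc(NC(=O)c2cc3cc([N+](=O)[O-])ccc3o2)c1` gives 25 ug/mL and compound 2 `COC(=O)c1ccc(NC(=O)c2cc3cc([N+](=O)[O-])ccc3o2)cc1` gives 20 ug/mL. The steps of a 1.3-fold lower number from compound 1 to compound 2 (0.10 log units; within the scatter) and no change at the digits printed from compound 1 to compound 3 (within the scatter) both stay within the scatter, so compound 1 stands level with compound 3 at the digits shown, the two together being the highest of the three numbers, with compound 2 not separable from either.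

Compound 4 `NCc1ccccc1NC(=O)c1cc2cc([N+](=O)[O-])ccc2o1` differs from compound 1 by aminomethyl in place of hydrogen on an aromatic carbon. For the measured compounds named here, no measured step adds an aminomethyl; the two measured steps add a methoxycarbonyl and moved the number little. The expected step in this assay is therefore uncertain, leaning toward a modest rise. Compound 4 is estimated at 45 ug/mL, between 12 ug/mL and 170 ug/mL. That estimate means an expected step of a 1.8-fold higher number from compound 1 to compound 4 (0.26 log units; within the scatter).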

Compound 4, solubility: 5 ug/mL
Compound 4: the middle estimate sits 9.0-fold (0.95 log units) above what was measured; the measured number lies below the stated range.
By their numbers in this assay, from the lowest: compound 4; then compounds 2, 1 and 3 (each within the scatter of the next).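

The aromatic ring of compound 1 is not insensitive to substitution: the methoxycarbonyl steps stayed within the scatter, but aminomethyl ortho to a large group gives a step beyond it in this assay, with a 5.0-fold lower number from compound 1 to compound 4 (0.70 log units; beyond the scatter). The direction is downward, even though the new group brings a hydrogen-bond donor and a hydrogen-bond acceptor. No measurement shown here accounts for this drop. On these data alone, whether it belongs to the aminomethyl itself or to its place remains open. A hydroxymethyl or a longer aminoethyl chain on that same carbon would help separate the two.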